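This account rests on a few compounds, and the source may have more. Where it says the series, first, only, none or still open, it means among the compounds named here.

Working notes on the series. For the measured compounds named here, in an ADME assay on microsomes from liver (Rattus norvegicus) for metabolic stability, with a stated time of 30 min, tested at 1 uM (on this read-out higher numbers stand for a more stable compound and lower numbers for a less stable compound), compound 2 `Cc1ccc(NC(=O)c2cccc(C(F)(F)F)c2)cc1N1Cc2cnc(Nc3cnn(C)c3)nc2N(C)C1=O` gives 98.4%, the highest of the three numbers so far. Compound 1 `CCN1CCN(C(=O)c2ccc(Nc3ncc4c(n3)N(C)C(=O)N(c3cc(NC(=O)c5cccc(C(F)(F)F)c5)ccc3C)C4)cn2)CC1` gives 38.3% and compound 3 `CCN1CCN(c2ccc(Nc3ncc4c(n3)N(C)C(=O)N(c3cc(NC(=O)c5cccc(C(F)(F)F)c5)ccc3C)C4)cn2)CC1` gives 19.2%, and both lie beyond the scatter from compound 2.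

The next compound to read is compound 4 `Cc1cc(Nc2ncc3c(n2)N(C)C(=O)N(c2cc(NC(=O)c4cccc(C(F)(F)F)c4)ccc2C)C3)n(C)n1`, which carries 1,3-dimethyl-1H-pyrazol-5-yl in place of 1-methyl-1H-pyrazol-4-yl on a nitrogen on an aromatic ring. The same change can be read as (1-methyl-1H-pyrazol-4-yl)amino to (1,3-dimethyl-1H-pyrazol-5-yl)amino.

Going by the values given here, no measured step swaps one pyrazole for another. Among the compounds with values here, the only single-place step available is a number 19.1 percentage points lower from compound 1 to compound 3 (beyond the scatter), a modest one, with 4-ethylpiperazin-1-yl in place of (4-ethylpiperazin-1-yl)carbonyl on an aromatic carbon. That step offers a guide to size only, and a weak one, and it says nothing firm about direction. Compound 2 at 98.4% leaves little room upward on this read-out, so any real movement is expected to be downward.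

Within the data shown here, the expected change is a number 16.4 percentage points lower from compound 2 to compound 4 (beyond the scatter), of about the size of the one measured step. For compound 4 the estimate is 82%, with an expected range from 55% to 98%.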

Compound 4, percent of the compound remaining: 82.3%
Estimate against measurement, compound 4: 0.3 percentage points below; the measured number falls inside the stated range.
By their numbers in this assay, from the lowest: compound 3; then compound 1; then compound 4; then compound 2.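

In this assay, for the compounds shown here, the position on the nitrogen on an aromatic ring responds to a change within the pyrazoles themselves, not only to the larger ethylpiperazine groups of the earlier compounds: 1,3-dimethyl-1H-pyrazol-5-yl in place of 1-methyl-1H-pyrazol-4-yl gives a number 16.1 percentage points lower from compound 2 to compound 4 (beyond the scatter). The two groups match in ring size, hetero atoms and counted hydrogen-bond donors and acceptors, yet the read-out still moves beyond the scatter, so those counts alone do not settle the number at this position; the added methyl and the change from 4-yl to 5-yl attachment arrive together in this one step and cannot be told apart. No measurement shown bears on what lies behind the lower number.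

Open, as far as these compounds go, is how 1-methyl-1H-pyrazol-5-yl would read, since it carries the 5-yl attachment without the added methyl, and whether it would stand nearer compound 2 or compound 4. Also open, from the compounds shown here alone, is how the same position would answer to a longer chain on the pyrazole, such as an ethyl in place of the methyl on nitrogen, or to a pyrazole carrying an amine.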